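Replacing the dimethylamino group on the pyridine arm

The compounds below may be only part of what the source reports. "The series", "measured", "known", "first", "only" and "open" are said of these compounds alone.

Two compounds share one core and were tested in an assay on isolated protein for binding affinity to corticotropin-releasing factor receptor 1 (Homo sapiens); on this read-out lower numbers stand for stronger inhibition and higher numbers for weaker inhibition. Compound 1 `CCCN(CCC)c1cc(C)nc2c(-c3ncc(N)cc3C)c(C)nn12` gives 85 nM in this assay. Compound 2 `CCCN(CCC)c1cc(C)nc2c(-c3ncc(C)cc3N(C)C)c(C)nn12` gives 23 nM in this assay, the lower of the two numbers, and the gap from compound 1 lies beyond the scatter. Compound 3 `CCCN(CCC)c1cc(C)nc2c(-c3ncc(C)cc3N=O)c(C)nn12` differs from compound 2 by a group of 2 heavy atoms (1 nitrogen, 1 oxygen; no ring) in place of a group of 3 heavy atoms (2 carbon, 1 nitrogen; no ring), on an aromatic carbon: a group of 2 heavy atoms in place of a group of 3 heavy atoms, on an aromatic carbon. Going by the values given here, no measured pair shows such a change, so a moderate weakening is expected, a 2.6-fold higher number from compound 2 to compound 3 (0.42 log units; beyond the scatter). Compound 3 is expected at 60 nM in this assay, within 20 nM to 200 nM.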

Compound 3, inhibition constant: > 10000 nM
Compound 3 was reported as a limit (the forecaster's own chance of this, stated with the estimate: 5%); middle value at least 160-fold (2.22 log units) away from the limit.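

The value for compound 3 is a limit, not a number: the limit of > 10000 nM in this assay, at which 1 of the 3 values shown sits. On this aromatic carbon, two atoms from the ring nitrogen, the group of 2 heavy atoms in place of dimethylamino gives an at least 430-fold higher number from compound 2 to compound 3 (2.63 log units; beyond the scatter), so a single small exchange here can cost nearly all measurable binding. The comparison with the other earlier compound gives an at least 110-fold higher number from compound 1 to compound 3 (2.07 log units; beyond the scatter), which places compound 3 behind both. The compounds shown leave open how an amine, a methoxy group or a longer chain on this carbon would read out, and what lies behind the loss.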